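The source may report more compounds than this note shows. Statements on the series, on what has been measured and on what is new or still open speak of the compounds shown alone.

Measured compounds:
Compound 1 `COc1cc2c(cc1N1C[C@@H](C)N(C)[C@@H](C)C1)N(C(=O)c1cccc(Cl)c1Cl)CC2` gives 251 nM in an assay on isolated protein for binding affinity to 5-hydroxytryptamine receptor 1D (Homo sapiens); on this read-out higher numbers stand for weaker inhibition and lower numbers for stronger inhibition.
Compound 2 `COc1cc2c(cc1N1C[C@@H](C)N(C)[C@@H](C)C1)N(C(=O)c1cccc(Cl)c1)CC2` gives 251 nM in this assay.
Compound 3 `COc1cc2c(cc1N1C[C@@H](C)N(C)[C@@H](C)C1)N(C(=O)Nc1cccc(Cl)c1F)CC2` gives 200 nM in this assay.

Compound 3 holds the lowest of the three numbers, yet its steps to the other two lie within the scatter: a 1.3-fold lower number from compound 1 to compound 3 (0.10 log units; within the scatter) and a 1.3-fold lower number from compound 2 to compound 3 (0.10 log units; within the scatter). Compound 4 `COc1cc2c(cc1N1C[C@@H](C)N(C)[C@@H](C)C1)N(C(=O)Nc1cccc(C(F)(F)F)c1Cl)CC2` differs from compound 3 by 2-chloro-3-(trifluoromethyl)phenyl in place of 3-chloro-2-fluorophenyl on an amide-type nitrogen. Among the compounds with values here, the steps that bear on this change all vary the aryl group attached to the carbonyl or to the amide-type nitrogen; the third, no change at the digits printed from compound 1 to compound 2 (within the scatter), is likewise within the scatter. Within the data shown here, no step in this assay so far moves the number beyond the scatter. Compound 4 is therefore expected to show no step beyond the scatter, a 1.1-fold higher number from compound 3 to compound 4 (0.04 log units; within the scatter). Compound 4 is estimated at 220 nM, with a range from 100 nM to 500 nM.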

Compound 4, inhibition constant: 50.1 nM
Beside the measured number, compound 4's estimate is 4.4-fold (0.64 log units) above it; the measured number lies below the stated range.
By their numbers in this assay, from the lowest: compound 4; then compounds 3, 1 and 2 (each within the scatter of the next).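

Putting 2-chloro-3-(trifluoromethyl)phenyl in place of 3-chloro-2-fluorophenyl on the amide-type nitrogen gives a 4.0-fold lower number from compound 3 to compound 4 (0.60 log units; beyond the scatter) in this assay. This is the first step among these compounds to pass the scatter, so the aryl group here can move the number, which the earlier aryl changes did not show. No measurement at hand accounts for this gain. From the compounds shown here alone, whether it belongs to the trifluoromethyl group or to the rearranged halogens stays open, since these differ together. Going by these compounds, how a nitrile or a methoxy group in place of trifluoromethyl would read also remains open.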